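Para-substituent swap on a spiro core: diethylamino to tert-butyl

The source may report more compounds than this note shows. Statements on the series, on what has been measured and on what is new or still open speak of the compounds shown alone.

Measured so far:
compound 1, `CCN(CC)c1ccc(N2C(=O)NC3(CSC4=C3C(=O)c3ncccc3C4=O)C2=O)cc1`: 730 nM
compound 2, `CCCCCc1ccc(N2C(=O)NC3(CSC4=C3C(=O)c3ncccc3C4=O)C2=O)cc1`: 830 nM

In a functional assay on XF498 cells (Homo sapiens) for antiproliferative activity, read by MTT assay, with a stated time of 96 h (a higher number here means a weaker inhibitor, a lower number a stronger inhibitor), compound 1 gives 730 nM and compound 2 gives 830 nM, the two numbers sitting within the scatter of each other. The one step shown, a 1.1-fold higher number from compound 1 to compound 2 (0.06 log units; within the scatter), replaces the diethylamino group with a pentyl chain and leaves the number essentially unchanged. Compound 3, `CC(C)(C)c1ccc(N2C(=O)NC3(CSC4=C3C(=O)c3ncccc3C4=O)C2=O)cc1`, is not yet measured; it differs from compound 1 by tert-butyl in place of diethylamino on an aromatic carbon. Going by the values given here, since the only comparable change, from diethylamino to pentyl, stayed within the scatter, a step of similar size, that is none beyond the scatter, is expected here, with perhaps a slight drift to a higher number. The estimate for compound 3 is therefore 900 nM, between 450 nM and 1800 nM, a step of a 1.2-fold higher number from compound 1 to compound 3 (0.09 log units; within the scatter).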

Compound 3, half-maximal inhibitory concentration: 850 nM
The estimate for compound 3 lay 1.1-fold (0.02 log units) above the measured number; measured number inside the range.
By their numbers in this assay, from the lowest: compounds 1, 2 and 3 (each within the scatter of the next).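

In this assay tert-butyl in place of diethylamino gives a 1.2-fold higher number from compound 1 to compound 3 (0.07 log units; within the scatter) and, in place of pentyl, gives a 1.0-fold higher number from compound 2 to compound 3 (0.01 log units; within the scatter) as a second within-scatter result. This position therefore now holds two carbon-only groups of different shape alongside diethylamino with no step beyond the scatter. No measurement shown explains this flat result.

The compounds shown leave open whether a carboxylic acid, a primary amine or a methyl group here would move the number beyond the scatter. They also leave open whether these swaps would behave alike on a changed core.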